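A few compounds are considered here, and "the series" means these few. Any claim that something is new, unique, unknown or untested is made for them only; others in the source may bear on it.

Measured values in a functional assay on DU-145 cells (Homo sapiens) for cytotoxicity, read by MTT assay; on this read-out higher numbers stand for weaker inhibition and lower numbers for stronger inhibition:

Compound 1 `CCCC(O)CC(=O)O[C@H](CC=C(C)C)C1=CC(=O)c2c(O)ccc(O)c2C1=O`: > 100000 nM (a limit of the assay, not a number)
Compound 2 `CCCCC(O)CC(=O)O[C@H](CC=C(C)C)C1=CC(=O)c2c(O)ccc(O)c2C1=O`: 45300 nM
Compound 3 `CCCC(CC(=O)O[C@H](CC=C(C)C)C1=CC(=O)c2c(O)ccc(O)c2C1=O)OC(C)=O`: 55700 nM

Compound 3 stands at 55700 nM and shows no real difference from its nearest neighbour, with a 1.2-fold higher number from compound 2 to compound 3 (0.09 log units; within the scatter) linking the two. Compound 4 `CC(C)=CC[C@@H](OC(=O)CC(O)c1ccccc1)C1=CC(=O)c2c(O)ccc(O)c2C1=O` carries hydroxy(phenyl)methyl in place of 1-acetoxybutyl on a saturated chain carbon bound to a carbonyl carbon and keeps a free hydroxy, as compound 1 and compound 2 do. Two more steps bear on this: an at least 2.2-fold lower number from compound 1 to compound 2 (0.34 log units; beyond the scatter) for a methyl added to the chain, and an at least 1.7-fold lower number from compound 1 to compound 3 (0.25 log units; that floor lies within the scatter) for acetyl on the oxygen. Both start from a limit, and neither involves a phenyl ring, so they are a weak guide. In this assay the expected result is a 1.2-fold lower number from compound 3 to compound 4 (0.09 log units; within the scatter), with no shift beyond the scatter foreseen. Estimated for compound 4 is 45000 nM, with an expected range of 15000 nM to 100000 nM.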

Compound 4, half-maximal inhibitory concentration: 17000 nM
Estimate against measurement, compound 4: 2.6-fold (0.42 log units) above, and the stated range covers the measured number.
By their numbers in this assay, from the lowest: compound 4; then compounds 2 and 3 (each within the scatter of the next). At a limit, above all of these: compound 1.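

In this assay, a phenyl ring on the carbon carrying the free hydroxy gives a clear drop in the number: a 2.7-fold lower number from compound 2 to compound 4 (0.43 log units; beyond the scatter) for phenyl in place of butyl, and a 3.3-fold lower number from compound 3 to compound 4 (0.52 log units; beyond the scatter), where the acetyl goes as well. This place therefore accepts an aromatic ring, and among the compounds shown the ring beats the chains. A third step, an at least 5.8-fold lower number from compound 1 to compound 4 (0.76 log units; beyond the scatter), starts from a limit and not a number: the limit of > 100000 nM in this assay, at which 1 of the 4 values shown sits.

The step from compound 3 changes two things at once, so the shares of the ring and the free hydroxy stay unresolved. Also open, as far as these compounds go, is how a pyridine ring or an amine would read at this place.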